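Trifluoromethoxy in Place of Fluoro: An Expectation

This account rests on a few compounds, and the source may have more. Where it says the series, first, only, none or still open, it means among the compounds named here.

Among the compounds with values here, compound 1 `Oc1cccc(-c2cc(-c3ccccc3F)cc(-c3cccc(O)c3)n2)c1` gives 11200 nM in a functional assay on DU-145 cells (Homo sapiens) for inhibition (a higher number here means a weaker inhibitor, a lower number a stronger inhibitor), the higher of the two numbers measured so far. Compound 2 `Oc1cccc(-c2cc(-c3ccc(F)cc3)cc(-c3cccc(O)c3)n2)c1` gives 7120 nM in this assay, and the step of a 1.6-fold lower number from compound 1 to compound 2 (0.20 log units; within the scatter) lies within the scatter, so the two compounds are not separated by these data. Compound 3 `Oc1cccc(-c2cc(-c3ccccc3OC(F)(F)F)cc(-c3cccc(O)c3)n2)c1` differs from compound 1 in one place: trifluoromethoxy in place of fluoro on an aromatic carbon. Within the data shown here, no measured step bears directly on this change; the one step on record, a 1.6-fold lower number from compound 1 to compound 2 (0.20 log units; within the scatter), concerns only where a fluoro sits and was within the scatter. With a larger group entering ortho to a large group and no guidance from a comparable step, compound 3 is expected to stay near compound 1, with the step of a 1.2-fold lower number from compound 1 to compound 3 (0.09 log units; within the scatter) estimated to fall within the scatter. Compound 3 is therefore estimated at 9000 nM in this assay, within a range from 3000 nM to 27000 nM.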

Compound 3, half-maximal inhibitory concentration: 5420 nM
Estimate against measurement, compound 3: 1.7-fold (0.22 log units) above; the range from low to high includes it.
By their numbers in this assay, from the lowest: compounds 3, 2 and 1 (each within the scatter of the next, the first and the last beyond it).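

Trifluoromethoxy in place of fluoro gives a 2.1-fold lower number from compound 1 to compound 3 (0.32 log units; beyond the scatter) in this assay, a modest step, but the first on record to lie beyond the scatter. The place ortho to a large group therefore takes a substituent of five heavy atoms instead of one with no loss, and the number even falls, which the step between compound 1 and compound 2 could not show. Nothing measured here accounts for this step, so what lies behind it stays unknown.

The compounds shown leave open whether the fall belongs to trifluoromethoxy alone or extends to other groups at this place, such as methoxy, an amine or a carboxylic acid. They also leave open how trifluoromethoxy would fare at the place that carries fluoro in compound 2.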